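Changing the Halogen Pattern on the Benzyloxy Ring

The source may hold more compounds than are shown below. What is called first, only, known or untested is meant among the compounds shown, and "the series" means these compounds.

Compound 1, `Cc1ccc(NC(=O)NC(=O)c2ccc(OCc3cccc(Cl)c3Cl)cc2)cc1-c1nc2ccccc2[nH]1`: 87000 nM
Compound 2, `Cc1ccc(NC(=O)NC(=O)c2ccc(OCc3ccc(Cl)cc3Cl)cc2)cc1-c1nc2ccccc2[nH]1`: 2550 nM
Compound 3, `Cc1ccc(NC(=O)NC(=O)c2ccc(OCc3ccc(F)cc3)cc2)cc1-c1nc2ccccc2[nH]1`: not yet measured

Of the compounds shown here, two built on one shared core have been tested in a functional assay on MNK45 cells (Homo sapiens) for inhibition, read by MTT assay, with a stated time of 48 h; a higher number here means a weaker inhibitor, a lower number a stronger inhibitor. Compound 1 gives 87000 nM, whereas compound 2 gives 2550 nM, and the change between them is a 34-fold lower number from compound 1 to compound 2 (1.53 log units; beyond the scatter). On these two numbers compound 2 stands lowest, the stronger inhibitor of the two by a margin well beyond the scatter.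

Compound 3 differs from compound 2 in one place: 4-fluorophenyl in place of 2,4-dichlorophenyl on a saturated chain carbon bound to an oxygen on an aromatic ring. Among the compounds with values here, only one measured step bears on this change, and only loosely. It shows that moving a single chlorine around the ring shifted the number greatly, a 34-fold lower number from compound 1 to compound 2 (1.53 log units; beyond the scatter), so the halogen pattern on this ring clearly matters. Within the data shown here, the new change removes one chlorine altogether and trades the other for fluorine, a pattern not yet tested, and no measured step tells its direction. On balance a weakening beyond the scatter is expected, with wide uncertainty: the estimated step is a 3.9-fold higher number from compound 2 to compound 3 (0.59 log units; beyond the scatter). Compound 3 is therefore estimated at 10000 nM, within a range from 2000 nM to 60000 nM.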

Compound 3, half-maximal inhibitory concentration: 240 nM
The estimate for compound 3 lay 42-fold (1.62 log units) above the measured number; the measured number lies below the stated range.
By their numbers in this assay, from the lowest: compound 3; then compound 2; then compound 1.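

Removing one chlorine and replacing the other with fluorine on this saturated chain carbon bound to an oxygen on an aromatic ring strengthens inhibition. In this assay the change gives an 11-fold lower number from compound 2 to compound 3 (1.03 log units; beyond the scatter) and, set against the weakest of the three, a 360-fold lower number from compound 1 to compound 3 (2.56 log units; beyond the scatter). Within the data shown here, the earlier pair showed only that the placement of two chlorines matters, whereas this result shows that a dichlorophenyl group is not required for the lowest number so far, which belongs to the 4-fluorophenyl group with its single halogen. Nothing available here accounts for the size or direction of this step.

Compound 3 differs from compound 2 by both the loss of a chlorine and the arrival of a fluorine, so the share of each in the step remains unresolved, and a plain phenyl group or a phenyl group carrying one chlorine would help to separate them. Going by these compounds, it also remains open how a non-halogen group on this ring, such as methoxy or methyl, would compare with the 4-fluorophenyl group.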